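Swapping Carboxy for Hydroxy in a Paw Edema Series

This account rests on a few compounds, and the source may have more. Where it says the series, first, only, none or still open, it means among the compounds named here.

Measured so far:
Compound 1, `COc1ccc(-n2nc(C(=O)Nc3ccc(C(F)(F)F)cc3)nc2-c2cc(OC)c(OC)c(OC)c2)cc1`: 83%
Compound 2, `COc1ccc(-n2nc(C(=O)Nc3ccc(C(=O)O)cc3)nc2-c2cc(OC)c(OC)c(OC)c2)cc1`: 95%

In a functional assay on the whole organism for inhibition, with Rattus norvegicus as the target, read by paw edema, with stated times of 30 min and 3 h, at a dose of 0.28 mmol/kg by the oral route (on this read-out higher numbers stand for more inhibition at the one dose given (going by the name of the read-out) and lower numbers for less inhibition), compound 2 gives 95%, the higher of the two numbers recorded. For the measured compounds named here, compound 1 gives 83%, and the single measured step between them, a number 12 percentage points higher from compound 1 to compound 2 (beyond the scatter), is the only change in this set that has been followed by a measurement.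

Compound 3, `COc1ccc(-n2nc(C(=O)Nc3ccc(O)cc3)nc2-c2cc(OC)c(OC)c(OC)c2)cc1`, has not yet been measured. It differs from compound 2 in one place: hydroxy in place of carboxy on an aromatic carbon. Going by the values given here, no measured step exchanges carboxy for hydroxy, so nothing here speaks to this change directly. Among the compounds with values here, the one step that exists, a number 12 percentage points higher from compound 1 to compound 2 (beyond the scatter), shows only that a group bearing one hydrogen-bond donor and one acceptor at this position went with a modest gain over trifluoromethyl; hydroxy keeps the same count of donor and acceptor, as stated above, but with fewer heavy atoms.

On that thin basis a small decrease, or no change beyond the scatter, is expected: a number 7 percentage points lower from compound 2 to compound 3 (within the scatter). Compound 3 is estimated at 88%, with a likely range from 74% to 98%.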

Compound 3, a percentage reported as inhibition, in the whole organism at one dose (the size of the read-out at that dose, not a potency): 64%
Compound 3: middle estimate off by 24 percentage points, on the high side; measured number below the stated range.
By their numbers in this assay, from the lowest: compound 3; then compound 1; then compound 2.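

In this assay carboxy and hydroxy carry the same count of hydrogen-bond donors and acceptors, yet the exchange gives a number 31 percentage points lower from compound 2 to compound 3 (beyond the scatter), so that count alone does not settle the outcome at this position. Hydroxy also falls short of trifluoromethyl, with a number 19 percentage points lower from compound 1 to compound 3 (beyond the scatter), whereas carboxy gave a number 12 percentage points higher from compound 1 to compound 2 (beyond the scatter), so among these three compounds, replacing trifluoromethyl can either raise or lower the number, depending on the group that enters. The data measure these differences but offer no measurement that accounts for them.

Three groups at one position cannot separate the effect of group size from that of the group's other features, and a methyl ester, a primary carboxamide or an amine in the same place would give further points of comparison. Going by these compounds, each number also comes from a single oral dose, so it remains open whether the same order of compounds would hold at other doses.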